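From Bromo to Nitro on Compound 3

A few compounds are considered here, and "the series" means these few. Any claim that something is new, unique, unknown or untested is made for them only; others in the source may bear on it.

Going by these compounds, three compounds have numbers so far, and a fourth is still untested. In an ADME assay on HaCaT cells (Homo sapiens) for inhibition, read by sulforhodamine B assay, with a stated time of 48 h (a lower number here means a stronger inhibitor of growth, a higher number a weaker inhibitor of growth), compound 1 (`CCOC(=O)c1nn(-c2ccccc2)c(-c2ccc(Br)cc2)c1CNC(C)(C)C`) gives 61700 nM; > 509000 nM (2 entries) as its record. The entry of compound 1 with a sign is a limit of the assay, not a number. In this assay compound 2 (`CCOC(=O)c1nn(-c2ccccc2)c(-c2ccc(C)cc2)c1CNC(C)(C)C`) gives 72100 nM; > 585000 nM (2 entries) as its record. Here too, the entry of compound 2 with a sign is only a limit. Going by the values given here, compound 3 (`CC(C)(C)NCc1c(C(=O)O)nn(-c2ccccc2)c1-c1ccc(Br)cc1`) stands at 366000 nM as its only number, and two further entries for it carry no single number. That number is higher than the plain numbers of compound 1 and compound 2, which means weaker growth inhibition on those entries.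

Compound 4 (`CC(C)(C)NCc1c(C(=O)O)nn(-c2ccccc2)c1-c1ccc([N+](=O)[O-])cc1`) has nitro in place of bromo on an aromatic carbon, so 4-bromophenyl becomes 4-nitrophenyl (nitro in place of bromo on an aromatic carbon). Among the compounds with values here, no measured pair here shows what this swap does, so no step beyond the scatter is expected in this assay in either direction. The estimate means a 1.0-fold lower number from compound 3 to compound 4 (0.02 log units; within the scatter) as an expected step, and it rests on compound 3 at 366000 nM alone. Compound 4 is estimated at 350000 nM as the expected value, with a likely range (120000 nM to 800000 nM).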

Compound 4, concentration for 50% growth inhibition: > 634000 nM
Compound 4: a limit, no number; the forecaster's own chance of this, stated with the estimate: 40%; middle value at least 1.8-fold (0.25 log units) from the limit.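

Going by these compounds alone, putting nitro in place of bromo, on an aromatic carbon para to a large group, gives the first step between two measured compounds in this assay: an at least 1.7-fold higher number from compound 3 to compound 4 (0.23 log units; that floor lies within the scatter). The entry of compound 4, > 634000 nM, is a limit of the assay and not a number. Going by these compounds, the change therefore shows no sign of stronger growth inhibition at this position, and the true size of the step stays unknown, as the reading stops at that limit: the limit of > 634000 nM in this assay, at which 1 of the 4 values shown sits.

On these data alone, whether another group in this place, such as methoxy or an amine, would give a plain number different from that of compound 3 remains open. Equally open, as far as these compounds go, is how nitro would behave with the ethyl ester that compound 1 and compound 2 carry in place of the carboxylic acid, given that each of those two records mixes a plain number with limits.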